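The source may report more compounds than this note shows. Statements on the series, on what has been measured and on what is new or still open speak of the compounds shown alone.

Compound 2 `O=C(O)CCc1ccc(NC(=O)c2nnc(Cc3ccccc3)s2)cc1` gives 3670 nM in a functional assay on CHO cells for agonist activity at Free fatty acid receptor 1 (Homo sapiens), read by FLIPR and calcium flux, tested at 1 uM (a higher number here means that more compound is needed for the effect, a lower number that less compound is needed), and so stands highest of the two numbers at hand. Compound 1 `O=C(O)CCc1ccc(NC(=O)c2nnc(COc3ccc4c(c3)CCC4)s2)cc1` gives 1380 nM in this assay. Within the data shown here, the single measured step, a 2.7-fold higher number from compound 1 to compound 2 (0.42 log units; beyond the scatter), concerns another part of the molecule and does not bear directly on the present change. Compound 3 `O=C(O)CCc1ccc(NC(=O)c2nnc(Cc3cccc(Cl)c3)s2)cc1` differs from compound 2 by chloro in place of hydrogen on an aromatic carbon, sitting meta to a large group. Among the measured compounds shown here, with no comparable step among the measured compounds, the expected change is a 1.1-fold lower number from compound 2 to compound 3 (0.06 log units; within the scatter), nothing beyond the scatter. Compound 3 is therefore estimated at 3200 nM in this assay, within 1400 nM to 7500 nM.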

Compound 3, half-maximal effective concentration: 2390 nM
Compound 3: middle estimate off by 1.3-fold (0.13 log units), on the high side; the range from low to high includes it.
By their numbers in this assay, from the lowest: compounds 1, 3 and 2 (each within the scatter of the next, the first and the last beyond it).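

Chloro in place of hydrogen on this aromatic carbon, meta to a large group, gives a 1.5-fold lower number from compound 2 to compound 3 (0.19 log units; within the scatter), so in this assay the 3-chlorobenzyl group reads the same as benzyl within repeated measurement. The step of 3-chlorophenyl in place of (2,3-dihydro-1H-inden-5-yl)oxy, a 1.7-fold higher number from compound 1 to compound 3 (0.24 log units; within the scatter), also stays inside the scatter, unlike the earlier step to the unsubstituted phenyl. No evidence at hand accounts for this result. From the compounds shown here alone, whether a methoxy or trifluoromethyl group here, or chloro on another carbon of the ring, would read alike remains open.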